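This account rests on a few compounds, and the source may have more. Where it says the series, first, only, none or still open, it means among the compounds named here.

In a functional assay on CCRF-CEM cells (Homo sapiens) (a higher number here means that more compound is tolerated, a lower number that less compound is tolerated), compound 3 `COC(=O)CCCCn1c(=O)c(C)cn([C@@H]2O[C@H](CO[Si](C)(C)C(C)(C)C)[C@@]3(OS(=O)(=O)C=C3N)[C@H]2O[Si](C)(C)C(C)(C)C)c1=O` gives 125000 nM, and the nearest number comes from compound 2 `Cc1cn([C@@H]2O[C@H](CO[Si](C)(C)C(C)(C)C)[C@@]3(OS(=O)(=O)C=C3N)[C@H]2O[Si](C)(C)C(C)(C)C)c(=O)n(CC(=O)N(C)C)c1=O`, at 245000 nM. Compound 1 `COC(=O)Cn1c(=O)c(C)cn([C@@H]2O[C@H](CO[Si](C)(C)C(C)(C)C)[C@@]3(OS(=O)(=O)C=C3N)[C@H]2O[Si](C)(C)C(C)(C)C)c1=O` reports only a limit, > 152000 nM. Compound 4 `Cc1cn([C@@H]2O[C@H](CO[Si](C)(C)C(C)(C)C)[C@@]3(OS(=O)(=O)C=C3N)[C@H]2O[Si](C)(C)C(C)(C)C)c(=O)n(C/C=C/CO)c1=O` brings a change on a saturated chain carbon bound to an aromatic nitrogen: 3-hydroxyprop-1-en-1-yl in place of 3-(methoxycarbonyl)propyl on a saturated chain carbon bound to an aromatic nitrogen. Two measured steps alter the group at this same place: a 2.0-fold lower number from compound 2 to compound 3 (0.29 log units; within the scatter) and an at least 1.2-fold lower number from compound 1 to compound 3 (0.08 log units; that floor lies within the scatter). Neither shows a change beyond the scatter, and the second is only a floor. With only these steps to go on, no change beyond the scatter is expected in this assay. The expected step is a 1.2-fold higher number from compound 3 to compound 4 (0.08 log units; within the scatter). Compound 4 is estimated at 150000 nM, with an expected range of 70000 nM to 300000 nM.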

Compound 4, half-maximal cytotoxic concentration: 4410 nM
Estimate against measurement, compound 4: 34-fold (1.53 log units) above; the measured number lies below the stated range.
By their numbers in this assay, from the lowest: compound 4; then compounds 3 and 2 (each within the scatter of the next).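

In this assay, the place on a saturated chain carbon bound to an aromatic nitrogen turns out to be sensitive: 3-hydroxyprop-1-en-1-yl in place of 3-(methoxycarbonyl)propyl gives a 28-fold lower number from compound 3 to compound 4 (1.45 log units; beyond the scatter), and in place of dimethylcarbamoyl it gives a 56-fold lower number from compound 2 to compound 4 (1.74 log units; beyond the scatter). Going by these compounds alone, in place of methoxycarbonyl it gives an at least 34-fold lower number from compound 1 to compound 4 (1.53 log units; beyond the scatter), so all three steps lie beyond the scatter, unlike the earlier steps at this place. That last step starts from a limit, not a number: the limit of > 152000 nM in this assay, at which 1 of the 4 values shown sits.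

The compounds shown do not separate the terminal hydroxyl from the chain double bond. A saturated 4-hydroxybutyl chain or a 4-aminobut-2-en-1-yl group would tell these apart.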